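The source may hold more compounds than are shown below. What is called first, only, known or untested is meant among the compounds shown, and "the series" means these compounds.

Measured compounds:
compound 1 `NC(=O)NC(=O)c1cc(NC(=O)CBr)ccc1Cl`: 540 nM
compound 2 `COc1ccc(NC(=O)CBr)cc1C(=O)NC(N)=O`: 1570 nM
compound 3 `NC(=O)NC(=O)c1ccc(Cl)c(NC(=O)CCl)c1`: 15900 nM

All three were run in a functional assay on CCRF-CEM cells (Homo sapiens) for antiproliferative activity, read by trypan blue exclusion, with a stated time of 72 h; on this read-out lower numbers stand for stronger inhibition and higher numbers for weaker inhibition. Going by the values given here, compound 1 gives 540 nM and compound 2 gives 1570 nM; the one change between them, (methoxy in place of chloro on an aromatic carbon), gives a 2.9-fold higher number from compound 1 to compound 2 (0.46 log units; beyond the scatter). Among the compounds with values here, compound 3 stands apart with 15900 nM, the highest of the three numbers; the difference between its core and the core of compound 1 is not broken down here, and no single step to compound 3 is counted.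

Compound 4 `COc1ccc(C(=O)NC(N)=O)cc1NC(=O)CCl` is not yet measured. It differs from compound 3 by methoxy in place of chloro on an aromatic carbon, which is the same kind of change as that from compound 1 to compound 2, though not the same: in the earlier pair the site is ortho to a carbamoylcarbamoyl group and para to a ((bromomethyl)carbonyl)amino group, whereas in compound 3 it is ortho to a ((chloromethyl)carbonyl)amino group and para to a carbamoylcarbamoyl group. Within the data shown here, only one earlier instance of this change is available, so the expectation rests on it alone.

Because compound 3 already stands at 15900 nM and the earlier change gave a 2.9-fold higher number from compound 1 to compound 2 (0.46 log units; beyond the scatter), compound 4 is expected to move by about a 2.5-fold higher number from compound 3 to compound 4 (0.40 log units; beyond the scatter) in this assay. The estimated value for compound 4 is 40000 nM, within an expected range from 14000 nM to 120000 nM; a number this high may be reported only as a limit.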

Compound 4, half-maximal inhibitory concentration: > 20000 nM
Compound 4: a limit, no number; the forecaster's own chance of this, stated with the estimate: 25%; the middle value is on the limit's open side.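

In this assay compound 4 gives > 20000 nM, which is a limit of the assay and not a number. The step on this core can therefore be read only as a floor, an at least 1.2-fold higher number from compound 3 to compound 4 (0.09 log units; that floor lies within the scatter), so it does not go against the step on the core of compound 1, but it does not by itself confirm that the number rises on this core. Set side by side, the two steps show no measured disagreement and no established agreement, so neither transfer of the change nor a difference between the cores is shown: the same change on two cores in this assay, a 2.9-fold higher number (0.46 log units; beyond the scatter) from compound 1 to compound 2 and an at least 1.2-fold higher number (0.09 log units; that floor lies within the scatter) from compound 3 to compound 4; the limit leaves it open whether they differ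

The compounds shown leave open how large the effect of methoxy in place of chloro is on the core of compound 3, and whether it would read differently with other groups on that aromatic carbon, such as a fluoro, a methyl or a longer alkoxy chain. They also leave open how the series would respond if a carboxylic acid or an amine took the place of the carbamoylcarbamoyl group, with the chloro or the methoxy held fixed.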